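The source may hold more compounds than are shown below. What is called first, only, known or untested is meant among the compounds shown, and "the series" means these compounds.

Measured compounds:
- compound 1, `CC1CCN(c2c(S(=O)(=O)c3ccccc3)cnc3cc(Cl)ccc23)CC1`: 93%
- compound 2, `Cc1ccc(S(=O)(=O)c2cnc3ccc(Cl)cc3c2N2CCC(C)CC2)cc1F`: 68%

In an assay on isolated protein for displacement of a labelled ligand from metabotropic glutamate receptor 5 (Homo sapiens), with a stated time of 60 min, tested at 1 uM (a lower number here means less inhibition, a higher number more inhibition at the concentration tested (going by the name of the read-out)), compound 1 gives 93%, the higher of the two numbers. Among the measured compounds shown here, compound 2 gives 68%, a number well below it and beyond the scatter; because the two structures differ in more than one place, no single step links them, and the two values simply stand side by side.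

Compound 3, `Cc1ccc(S(=O)(=O)c2cnc3cc(Cl)ccc3c2N2CCC(C)CC2)cc1C`, has not yet been measured. It differs from compound 1 in one place: 3,4-dimethylphenyl in place of phenyl on a sulfonyl sulfur. For the measured compounds named here, no measured pair shows what adding methyl groups to this phenyl does on its own. Compound 2, which also carries a substituted phenyl on the sulfonyl, gives 68%, which points toward some loss. For compound 3 a modest fall is expected, a number 11 percentage points lower from compound 1 to compound 3 (beyond the scatter), near the edge of the scatter. Compound 3 is estimated at 82%, between 62% and 95%.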

Compound 3, a percentage reported as inhibition, at one concentration (the size of the read-out at that concentration, not a potency): 86%
For compound 3 the middle estimate is 4 percentage points below the measured one; measured number inside the range.
By their numbers in this assay, from the lowest: compound 2; then compounds 3 and 1 (each within the scatter of the next).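

In this assay, placing 3,4-dimethylphenyl in place of phenyl on a sulfonyl sulfur gives a number 7 percentage points lower from compound 1 to compound 3 (within the scatter). Among the compounds shown here, this position therefore accepts two added methyl groups on the phenyl without a difference that can be told apart from ordinary repeat scatter, which no earlier pair could show. Nothing available explains this outcome in terms of a measured property.

The compounds shown leave open what each methyl group does alone, and how an amine, a carboxylic acid or a longer chain such as butyl on this phenyl would fare. Since these readings come from a single concentration, they also leave open whether compound 1 and compound 3 would separate in a full potency measurement.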